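Cytotoxicity Outlook for Compound 4 on Huh-7.5 Cells

The source may hold more compounds than are shown below. What is called first, only, known or untested is meant among the compounds shown, and "the series" means these compounds.

Compound 1 `CN1CCCN(c2ccc(C#N)c(CN3CCN(C(c4ccc(F)cc4)c4ccc(F)cc4)CC3)c2)CC1` was examined in a toxicity assay on Huh-7.5 cells (Homo sapiens) for cytotoxicity, read by MTT assay, with a stated time of 96 h (a higher number here means that more compound is tolerated, a lower number that less compound is tolerated), where compound 1 gives 6240 nM. Compound 2 `N#Cc1ccc(NCCCn2ccnc2)cc1CN1CCN(C(c2ccc(F)cc2)c2ccc(F)cc2)CC1` carries (3-(1H-imidazol-1-yl)propyl)amino in place of 4-methyl-1,4-diazepan-1-yl on an aromatic carbon; in this assay compound 2 gives 5890 nM, and the step is a 1.1-fold lower number from compound 1 to compound 2 (0.03 log units; within the scatter). Compound 3 `CN1CCCN(c2ccc(C#N)c(CN3CCN(C(c4ccccc4)c4ccc(Cl)cc4)CC3)c2)CC1` rests on a different core, and how the cores of compound 1 and compound 3 differ is not broken down here. In this assay compound 3 gives 7340 nM, a number that lies within the scatter of those of compound 1 and compound 2. Compound 4 `N#Cc1ccc(NCCCn2ccnc2)cc1CN1CCN(C(c2ccccc2)c2ccc(Cl)cc2)CC1` is not yet measured; it differs from compound 3 by (3-(1H-imidazol-1-yl)propyl)amino in place of 4-methyl-1,4-diazepan-1-yl on an aromatic carbon, the same change that separates compound 1 from compound 2. For compound 4 a step of a 1.1-fold lower number from compound 3 to compound 4 (0.04 log units; within the scatter) is expected, resting on the step of a 1.1-fold lower number from compound 1 to compound 2 (0.03 log units; within the scatter), which lies within the scatter. Compound 4 is therefore estimated at 6700 nM, with a range from 3500 nM to 13000 nM.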

Compound 4, half-maximal cytotoxic concentration: 5380 nM
Estimate against measurement, compound 4: 1.2-fold (0.10 log units) above, and the stated range covers the measured number.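

In this assay, putting (3-(1H-imidazol-1-yl)propyl)amino in place of 4-methyl-1,4-diazepan-1-yl gives a 1.4-fold lower number from compound 3 to compound 4 (0.13 log units; within the scatter), and setting this beside the earlier pair shows no difference between the two cores: the same change on two cores in this assay, a 1.1-fold lower number (0.03 log units; within the scatter) from compound 1 to compound 2 and a 1.4-fold lower number (0.13 log units; within the scatter) from compound 3 to compound 4, 1.3-fold (0.11 log units) apart, within the scatter of two such steps. On these two cores, then, the change carries over with every step inside the scatter. Among the compounds shown here, this does not show that the change would behave the same way on any other core, since it rests on only two pairs of compounds.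

The compounds shown leave open how the number would respond to a carboxylic acid or a simple primary amine on that aromatic carbon. They also leave open what a longer chain to the imidazole ring would do.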